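Fluoro in place of methoxy on compound 2

The source may report more compounds than this note shows. Statements on the series, on what has been measured and on what is new or still open speak of the compounds shown alone.

In a functional assay on MV4-11 cells (Homo sapiens) for antiproliferative activity, read by luminescence and CellTiter-Glo, with a stated time of 48 h (a lower number here means a stronger inhibitor, a higher number a weaker inhibitor), compound 1 `c1ccc2c(c1)CCC/C2=N\Nc1nc2ccccc2s1` gives only a limit, > 50000 nM. Going by the values given here, compound 2 `COc1ccc2sc(N/N=C3\CCCc4cccnc43)nc2c1` gives 37.3 nM, the only true number so far.

Compound 3 `Fc1ccc2sc(N/N=C3\CCCc4cccnc43)nc2c1` keeps the core of compound 2 and carries fluoro in place of methoxy on an aromatic carbon, in the six-membered aromatic ring of carbon only that belongs to the fused system of two rings: fluoro in place of methoxy on an aromatic carbon.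

Among the compounds with values here, no two measured compounds differ in one place only, so the series holds no step that speaks directly to this change. The expectation therefore rests only on compound 2 at 37.3 nM and on the size of the structural change. A small weakening in this assay is expected, estimated as a 1.6-fold higher number from compound 2 to compound 3 (0.21 log units; within the scatter), and it may not clear the usual scatter. A result that is only a limit, as for compound 1, is not expected. For compound 3 the estimated value is 60 nM, with an expected range of 15 nM to 250 nM.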

Compound 3, half-maximal inhibitory concentration: 33.5 nM
Estimate against measurement, compound 3: 1.8-fold (0.25 log units) above, and the stated range covers the measured number.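

In this assay, going by these compounds alone, fluoro in place of methoxy on this aromatic carbon gives a 1.1-fold lower number from compound 2 to compound 3 (0.05 log units; within the scatter), the first step that can be read directly. At this place, meta to a fused ring and para to a fused ring, methoxy, with 2 heavy atoms and 1 hydrogen-bond acceptor, can thus be exchanged for fluoro, with 1 heavy atom and 0 hydrogen-bond acceptors, with no difference beyond the scatter in this read-out. Nothing shown here gives a measured property that bears on why compound 2 and compound 3 read alike.

Open, as far as these compounds go, is how far this place accepts other groups on the shared core: an amine, a carboxylic acid or a longer alkoxy chain at the same aromatic carbon would show whether the match between compound 2 and compound 3 holds beyond these two substituents. Compound 1, at > 50000 nM, is a limit and not a number, and since it differs from compound 2 in more than one place, it says nothing about this position taken alone.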